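Removing the 4-Methoxyphenyl Group from Compound 1

The source may hold more compounds than are shown below. What is called first, only, known or untested is meant among the compounds shown, and "the series" means these compounds.

Compound 1 `COc1ccc(C2=C(c3ccccc3)C3(C=CC(=O)C=C3)OC2=O)cc1` was tested in a functional assay on MCF7 cells (Homo sapiens) for antiproliferative activity, read by MTT assay, with a stated time of 48 h (on this read-out lower numbers stand for stronger inhibition and higher numbers for weaker inhibition), and gave 5860 nM. Among the three measured compounds this is the highest number, but compound 3 `COc1cc(C2=C(c3ccccc3)C3(C=CC(=O)C=C3)OC2=O)cc(OC)c1OC` gives 5790 nM and compound 2 `O=C1C=CC2(C=C1)OC(=O)C(c1ccc(CO)cc1)=C2c1ccccc1` gives 5760 nM, so all three sit within the scatter of one another. For the measured compounds named here, the one single-point step in this set, a 1.0-fold lower number from compound 1 to compound 2 (0.01 log units; within the scatter), exchanges a substituent on the aryl ring and leaves the number unchanged.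

Compound 4 `O=C1C=CC2(C=C1)OC(=O)C=C2c1ccccc1` is reached from compound 1 by a different kind of change: hydrogen in place of 4-methoxyphenyl on a double-bonded ring carbon. Going by the values given here, no measured step removes a whole aryl ring from this position; the step from compound 1 to compound 2 only varies what sits on that ring, and compound 3 only adds further methoxy groups to it. The available data therefore give no direct anchor for this change, and the estimate for compound 4 carries a wide range.

On that basis compound 4 is expected to give 12000 nM in this assay, within 4000 nM to 40000 nM. This corresponds to an expected 2.0-fold higher number from compound 1 to compound 4 (0.31 log units; beyond the scatter).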

Compound 4, half-maximal inhibitory concentration: 6460 nM
Compound 4: the middle estimate sits 1.9-fold (0.27 log units) above what was measured, and the stated range covers the measured number.
By their numbers in this assay, from the lowest: compounds 2, 3, 1 and 4 (each within the scatter of the next).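

In this assay, the whole 4-methoxyphenyl group can give way to hydrogen on the double-bonded ring carbon with no readable effect, at a 1.1-fold higher number from compound 1 to compound 4 (0.04 log units; within the scatter). The same holds for the loss of 4-(hydroxymethyl)phenyl, at a 1.1-fold higher number from compound 2 to compound 4 (0.05 log units; within the scatter), so among these compounds neither the substituents on this aryl ring nor the ring itself separates the numbers. No available evidence accounts for this result.

On these data alone, it remains open whether an amine, a carboxylic acid or a longer alkyl chain on this same ring carbon would stay within the scatter of these four compounds or move the number away from them. As far as these compounds go, all four compounds also keep the phenyl group on the neighbouring ring atom named in the comparison, so what that phenyl group contributes to the number remains unknown.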